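The source may hold more compounds than are shown below. What is called first, only, known or untested is meant among the compounds shown, and "the series" means these compounds.

Compound 1 `COc1ccc(C(=O)ON=C2CC(c3ccc(O)c(OC)c3)N(C)C(c3ccc(O)c(OC)c3)C2)cc1` is one of three compounds that share a core and differ only in the group attached through the oxygen of the oxime. In a functional assay, read by spectrophotometry, with a stated time of 30 min (a higher number here means a weaker inhibitor, a lower number a stronger inhibitor), compound 1 gives 33000 nM, the highest of the three numbers measured. Compound 2 `COc1cc(C2CC(=NOC(=O)c3cccc(O)c3)CC(c3ccc(O)c(OC)c3)N2C)ccc1O` gives 16500 nM in this assay, and compound 3 `COc1cc(C2CC(=NOC(=O)c3ccc(O)cc3)CC(c3ccc(O)c(OC)c3)N2C)ccc1O` gives 15100 nM. The steps from compound 1 are a 2.0-fold lower number from compound 1 to compound 2 (0.30 log units; within the scatter) and a 2.2-fold lower number from compound 1 to compound 3 (0.34 log units; beyond the scatter), so swapping one aryl ester for another moves the number only modestly.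

Compound 4 `COc1cc(C2CC(=NO)CC(c3ccc(O)c(OC)c3)N2C)ccc1O` goes further: hydrogen in place of (4-methoxyphenyl)carbonyl on an oxygen. Among the compounds with values here, no measured step removes the whole (4-methoxyphenyl)carbonyl group, so the two aryl-swap steps bear on it only loosely, showing that this part of the molecule does not drive large changes among the three measured compounds. A step of about the same modest size, in either direction, is expected, and the estimate for compound 4 is 28000 nM, within the range 7000 nM to 110000 nM. That expected step, a 1.2-fold lower number from compound 1 to compound 4 (0.07 log units; within the scatter), would be within the scatter.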

Compound 4, half-maximal inhibitory concentration: 158000 nM
Beside the measured number, compound 4's estimate is 5.6-fold (0.75 log units) below it, outside the stated range (above it).
By their numbers in this assay, from the lowest: compounds 3, 2 and 1 (each within the scatter of the next, the first and the last beyond it); then compound 4.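

Removing the whole aryl carbonyl group from the oxime oxygen matters more in this assay than exchanging one aryl group for another, with a 4.8-fold higher number from compound 1 to compound 4 (0.68 log units; beyond the scatter) and a 9.6-fold higher number from compound 2 to compound 4 (0.98 log units; beyond the scatter) and also a 10-fold higher number from compound 3 to compound 4 (1.02 log units; beyond the scatter) when each ester gives way to hydrogen. All three esters therefore have lower numbers than compound 4, so an aryl carbonyl group at this oxygen goes with stronger inhibition than hydrogen, whichever of the three aryl groups it carries. No measurement shown here explains this gap.

The compounds shown leave open whether the gain needs the carbonyl, the aromatic ring or both, since none of them has an acetyl group or a benzyl group on this oxygen. Going by these compounds, it also remains open how an aryl ester bearing an amine or a carboxylic acid would read.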